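The source may report more compounds than this note shows. Statements on the series, on what has been measured and on what is new or still open speak of the compounds shown alone.

Measured so far:
compound 1, `Oc1cccc(-c2cc(-c3ccc(C(F)(F)F)cc3)cc(-c3ccccc3O)n2)c1`, > 50000 nM;
compound 2, `Oc1ccc(-c2cc(-c3cccc(C(F)(F)F)c3)cc(-c3ccccc3O)n2)cc1`, > 50000 nM.

In a functional assay on T47D cells (Homo sapiens) for inhibition (on this read-out higher numbers stand for weaker inhibition and lower numbers for stronger inhibition), compound 2 gives only a limit of > 50000 nM, not a number. Compound 1 likewise stops at a limit of > 50000 nM in this assay. Both measured values thus sit at the same limit, as the limit of > 50000 nM in this assay, at which 2 of the 2 values shown sit, states, so no ranking between them can be drawn. Compound 3, `Oc1ccc(-c2cc(-c3ccc(C(F)(F)F)cc3)cc(-c3ccccc3O)n2)cc1`, has not yet been tested in this assay. It differs from compound 2 by 4-(trifluoromethyl)phenyl in place of 3-(trifluoromethyl)phenyl on an aromatic carbon. Since both measured compounds return only a limit, no step beyond the scatter is expected in this assay for this change. The step that the estimate for compound 3 means is expected to be a number no higher from compound 2 to compound 3 (the limit leaves the size open). Compound 3 is expected to give about 50000 nM in this assay, within the range 20000 nM to 100000 nM, and most likely again reported only as a limit.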

Compound 3, half-maximal inhibitory concentration: > 50000 nM
Compound 3 ended at the assay's limit (the forecaster's own chance of this, stated with the estimate: 85%); the middle value sits exactly at the limit.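

Compound 1, compound 2 and compound 3 all stop at a limit, so neither step to compound 3 can be read in this assay: the limit of > 50000 nM in this assay, at which 3 of the 3 values shown sit. The compounds shown leave open whether swapping 3-(trifluoromethyl)phenyl for 4-(trifluoromethyl)phenyl, or 3-hydroxyphenyl for 4-hydroxyphenyl, changes inhibition at all.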